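The source may hold more compounds than are shown below. What is called first, only, known or untested is meant among the compounds shown, and "the series" means these compounds.

Measured so far in a functional assay on SK-BR-3 cells (Homo sapiens) for antiproliferative activity, read by MTT assay, with a stated time of 72 h; a higher number here means a weaker inhibitor, a lower number a stronger inhibitor:
Compound 1, `CCN1CCN(c2cc(C)c3cc(NC(=O)c4ccc(OC)cc4)ccc3n2)CC1`, gives 9000 nM.
Compound 2, `CCN1CCN(c2cc(C)c3cc(NC(=O)c4ccc(Cl)c(Cl)c4)ccc3n2)CC1`, gives 2160 nM.
Compound 3, `CCN1CCN(c2cc(C)c3cc(NC(=O)c4ccccc4)ccc3n2)CC1`, gives 18400 nM.

Of the three, compound 3 gives the highest number: a 2.0-fold higher number from compound 1 to compound 3 (0.31 log units; beyond the scatter), and an 8.5-fold higher number from compound 2 to compound 3 (0.93 log units; beyond the scatter).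

Compound 4, `CCN1CCN(c2cc(C)c3cc(NC(=O)c4ccccc4Br)ccc3n2)CC1`, is not yet measured. It differs from compound 3 by bromo in place of hydrogen on an aromatic carbon. The steps on the same benzoyl ring bear on it: a 4.2-fold lower number from compound 1 to compound 2 (0.62 log units; beyond the scatter) and an 8.5-fold higher number from compound 2 to compound 3 (0.93 log units; beyond the scatter), both tying halogen on that ring to a lower number, while a 2.0-fold higher number from compound 1 to compound 3 (0.31 log units; beyond the scatter) shows that removing a group raised it. Since a single bromo ortho to a large group is less than the two chloro groups behind an 8.5-fold higher number from compound 2 to compound 3 (0.93 log units; beyond the scatter), a smaller step downward is expected: a 2.0-fold lower number from compound 3 to compound 4 (0.31 log units; beyond the scatter). Compound 4 is therefore estimated at 9000 nM, between 3500 nM and 25000 nM.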

Compound 4, half-maximal inhibitory concentration: 39200 nM
For compound 4 the middle estimate is 4.4-fold (0.64 log units) below the measured one; measured number outside the range, above it.
By their numbers in this assay, from the lowest: compound 2; then compound 1; then compound 3; then compound 4.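

In this assay, bromo in place of hydrogen on an aromatic carbon ortho to a large group gives a 2.1-fold higher number from compound 3 to compound 4 (0.33 log units; beyond the scatter), so halogen on this benzoyl ring does not by itself go with a lower number. The 2-bromophenyl group in place of 3,4-dichlorophenyl gives an 18-fold higher number from compound 2 to compound 4 (1.26 log units; beyond the scatter), and in place of 4-methoxyphenyl it gives a 4.4-fold higher number from compound 1 to compound 4 (0.64 log units; beyond the scatter). No supporting data explain these steps. The compounds shown leave open whether the bromo or its place carries the rise: they include no 4-bromophenyl or 2-chlorophenyl group. As far as these compounds go, how an amine on this ring would read also remains open.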